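Swapping a Fluorinated Chain for an Alkyne on the Ether

The source may hold more compounds than are shown below. What is called first, only, known or untested is meant among the compounds shown, and "the series" means these compounds.

Of the compounds shown here, three sharing one core have been measured in an assay on cells with melanin-concentrating hormone receptor 1 (Homo sapiens) as the target, read by radioligand binding; a lower number here means a stronger inhibitor, a higher number a weaker inhibitor. Compound 1 `CC1CCCC(Oc2cccc3ccc(N)nc23)C1` gives 640 nM. Compound 2 `Nc1ccc2cccc(OCCC3CCCCC3)c2n1` gives 808 nM. Compound 3 `Nc1ccc2cccc(OCCC(F)(F)F)c2n1` gives 722 nM, the second highest of the three numbers, yet its gaps to compound 1 and to compound 2 both lie within the scatter, so the three cannot be told apart. Within the data shown here, the only step between close neighbours runs a 1.1-fold lower number from compound 2 to compound 3 (0.05 log units; within the scatter): a change of the group on the chain that left the number essentially where it was.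

Compound 4 `CCC#CCOc1cccc2ccc(N)nc12` differs from compound 3 by but-1-yn-1-yl in place of 2,2,2-trifluoroethyl on a saturated chain carbon bound to an oxygen on an aromatic ring. This change again reworks the chain attached through the oxygen on the aromatic ring, the same region altered from compound 2 to compound 3 without effect beyond the scatter. Among the measured compounds shown here, with only that one step to lean on, the expected step in this assay is a 1.0-fold lower number from compound 3 to compound 4 (0.00 log units; within the scatter), nothing beyond the scatter. Compound 4 is therefore estimated at 720 nM, within a range from 300 nM to 1700 nM.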

Compound 4, half-maximal inhibitory concentration: > 2000 nM
Compound 4 was reported as a limit (the forecaster's own chance of this, stated with the estimate: 5%); middle value at least 2.7-fold (0.44 log units) away from the limit.
By their numbers in this assay, from the lowest: compounds 1, 3 and 2 (each within the scatter of the next). At a limit, above all of these: compound 4.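

In this assay, but-1-yn-1-yl in place of 2,2,2-trifluoroethyl gives an at least 2.7-fold higher number from compound 3 to compound 4 (0.44 log units; beyond the scatter). This shows that the group on this chain can matter, which the earlier change on the same chain did not show, with a 1.1-fold lower number from compound 2 to compound 3 (0.05 log units; within the scatter). The reading for compound 4 is a limit of the assay and not a number, so the step has a lower bound but no known full size: the limit of > 2000 nM in this assay, at which 1 of the 4 values shown sits.

The compounds shown leave open whether the triple bond itself goes with the step, and a plain pentyl chain carrying no triple bond would test this directly. As far as these compounds go, how a chain ending in an amine or a carboxylic acid would read at this position also remains open.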